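Compound 4: Isopropyl in Place of Methyl on the Saturated Ring

This account rests on a few compounds, and the source may have more. Where it says the series, first, only, none or still open, it means among the compounds named here.

Measured values in a functional assay on HCT-15 cells (Homo sapiens) for antiproliferative activity, read by sulforhodamine B assay; a higher number here means a weaker inhibitor of growth, a lower number a stronger inhibitor of growth:
compound 1, `CC1CC(=O)c2s/c(=N/c3ccccc3)oc2C1`: 2070 nM
compound 2, `CC1(C)CC(=O)c2s/c(=N/c3c(Cl)cc(Cl)cc3Cl)oc2C1`: > 30000 nM, a limit of the assay
compound 3, `CC1CC(=O)c2s/c(=N/c3c(Cl)cc(Cl)cc3Cl)oc2C1`: > 30000 nM, a limit of the assay

Compound 3 stands at the limit of this assay, (the limit of > 30000 nM in this assay, at which 2 of the 3 values shown sit). Compound 4, `CC(C)C1CC(=O)c2s/c(=N/c3c(Cl)cc(Cl)cc3Cl)oc2C1`, differs from compound 3 by isopropyl in place of methyl on a saturated ring carbon. For the measured compounds named here, only one measured step touches the same carbon: a step that the two limits leave unreadable from compound 2 to compound 3, whose size the two limits leave unreadable. Going by the values given here, compound 1, which carries no chlorines on its aromatic ring, gives 2070 nM in this assay, but no step from it to compound 3 is computed, so its value shows only that a number can be reached within the shared core. With the nearest comparison unreadable, the expected step of a number no higher from compound 3 to compound 4 (the limit leaves the size open) carries no claimed direction. Compound 4 is therefore expected to remain at the limit, with an estimate of 30000 nM, ranging from 10000 nM to 100000 nM.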

Compound 4, concentration for 50% growth inhibition: > 30000 nM
Compound 4 ended at the assay's limit; the forecaster's own chance of this, stated with the estimate: 70%; the middle value sits exactly at the limit.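

Compound 3 and compound 4 both stand only as limits in this assay, so no step between them can be read: the limit of > 30000 nM in this assay, at which 3 of the 4 values shown sit.

The compounds shown leave open whether isopropyl in place of methyl changes growth inhibition at all.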